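A few compounds are considered here, and "the series" means these few. Any claim that something is new, unique, unknown or untested is made for them only; others in the source may bear on it.

Measured so far in a functional assay on KG-1 cells (Homo sapiens) for cytotoxicity, read by luminescence and CellTiter-Glo, with a stated time of 3 days; on this read-out higher numbers stand for weaker inhibition and lower numbers for stronger inhibition:

compound 1, `O=C(Nc1ccc(OC(F)(F)F)cc1)c1cc(F)ccc1O`: 780 nM
compound 2, `Cc1ccc(C(=O)Nc2ccc(C#N)cc2)c(O)c1`: 2560 nM
compound 3, `O=C(Nc1ccc(C(F)(F)F)c(Cl)c1)c1cc(Cl)ccc1O`: 450 nM

Compound 1 stands second highest of the three numbers. Its value and that of compound 3 lie within the usual scatter of each other, so no order can be read between them, while compound 2 sits at a higher number, beyond the scatter. Compound 4 `O=C(Nc1ccccc1)c1cc(F)ccc1O` has not yet been measured. It differs from compound 1 in one place: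

hydrogen in place of trifluoromethoxy on an aromatic carbon

Among the measured compounds shown here, no step of this kind between two measured compounds is available, so the size of its effect is unknown. The expectation is a modest loss of potency, with a step of a 3.2-fold higher number from compound 1 to compound 4 (0.51 log units; beyond the scatter). Compound 4 is estimated at 2500 nM, within a range from 900 nM to 7000 nM.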

Compound 4, half-maximal inhibitory concentration: > 10000 nM
Compound 4 gave a limit, no number; the forecaster's own chance of this, stated with the estimate: 10%; middle value at least 4.0-fold (0.60 log units) from the limit.
By their numbers in this assay, from the lowest: compounds 3 and 1 (each within the scatter of the next); then compound 2. At a limit, above all of these: compound 4.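

Putting hydrogen in place of trifluoromethoxy on this aromatic carbon gives an at least 12-fold higher number from compound 1 to compound 4 (1.10 log units; beyond the scatter) in this assay. For compound 4 the value > 10000 nM is a limit of the assay, not a number. Among the compounds shown here, all the earlier compounds carry a group on this carbon, and only compound 4 shows that losing the trifluoromethoxy group with nothing in its place costs much of the activity of compound 1.

From the compounds shown here alone, the true size of this step stays open: the limit of > 10000 nM in this assay, at which 1 of the 4 values shown sits. Also open, going by these compounds, is whether a smaller group on this carbon, such as methoxy or an amine, would keep the activity.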